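Sulfamate series: fluorophenyl to pyridinyl swap at compound 3

This account rests on a few compounds, and the source may have more. Where it says the series, first, only, none or still open, it means among the compounds named here.

Three compounds of the shared core have numbers in an assay on HEK293 cells for inhibition of Steryl-sulfatase (Homo sapiens), tested at 1 uM; on this read-out higher numbers stand for a stronger effect at the one concentration tested and lower numbers for a weaker effect. Compound 1 `NS(=O)(=O)Oc1ccc2c(c1)CN(C(=O)c1ccc(N3CCN(Cc4ccccc4)CC3)cc1)CC2` gives 75.8%, compound 2 `CCN(Cc1ccccc1)Cc1ccc(S(=O)(=O)N2CCc3ccc(OS(N)(=O)=O)cc3C2)cc1` gives 31%, and compound 3 `CCN(Cc1ccc(F)cc1)c1cccc(C(=O)N2CCc3ccc(OS(N)(=O)=O)cc3C2)c1` gives 66.5%. Compound 3 stands second highest of the three: its number and that of compound 1 lie within the scatter of each other, while the number of compound 2 lies beyond the scatter below it. Compound 4 `CCN(Cc1cccnc1)c1cccc(C(=O)N2CCc3ccc(OS(N)(=O)=O)cc3C2)c1` differs from compound 3 in one place: pyridin-3-yl in place of 4-fluorophenyl on a saturated chain carbon bound to a nitrogen on an aromatic ring. Among the measured compounds shown here, no measured pair shows this change, so its size is open; a modest loss, or none beyond the scatter, is expected. The step of a number 8.5 percentage points lower from compound 3 to compound 4 (within the scatter) is the expected outcome. Compound 4 is estimated at 58%, with a range from 40% to 75%.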

Compound 4, a percentage reported as inhibition, at one concentration (the size of the read-out at that concentration, not a potency): 33.5%
Beside the measured number, compound 4's estimate is 24.5 percentage points above it, and the stated range ends above it.
By their numbers in this assay, from the lowest: compounds 2 and 4 (each within the scatter of the next); then compounds 3 and 1 (each within the scatter of the next).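

In this assay, the place on a saturated chain carbon bound to a nitrogen on an aromatic ring proves sensitive to the ring it carries: pyridin-3-yl in place of 4-fluorophenyl gives a number 33 percentage points lower from compound 3 to compound 4 (beyond the scatter) and takes most of the effect away. Among the compounds shown here, the earlier compounds offered no single-place pair, so this is the first step that can be read. The compounds shown leave open whether the loss follows the ring nitrogen or the absent fluorine, which a 4-chlorophenyl or pyridin-4-yl group at this place could help separate. No available evidence bears on the cause of this step.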